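The compounds below may be only part of what the source reports. "The series", "measured", "known", "first", "only" and "open" are said of these compounds alone.

Compound 1, `Cc1cc(O)c(C2=NN(c3ccc(S(N)(=O)=O)cc3)C(/C=C/c3ccccc3)C2)cc1Cl`: 14700 nM in a functional assay on OVCAR-5 cells (Homo sapiens) for antiproliferative activity, with a stated time of 48 h; on this read-out lower numbers stand for stronger inhibition of growth and higher numbers for weaker inhibition of growth. Compound 2, `COc1ccc(C2CC(c3cc(Cl)c(C)cc3O)=NN2c2ccc(S(N)(=O)=O)cc2)cc1OC`: 6360 nM in this assay.

Within the data shown here, of the two measured compounds, compound 2 gives the lower number, and the only measured step, a 2.3-fold lower number from compound 1 to compound 2 (0.36 log units; beyond the scatter), separates it from compound 1.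

Compound 3, `COc1ccc(C2CC(c3cc(Cl)c(C)cc3O)=NN2c2ccc(S(N)(=O)=O)cc2)c(OC)c1OC`, is not yet measured. It differs from compound 2 in one place: methoxy in place of hydrogen on an aromatic carbon. The added methoxy sits on an aromatic carbon of a six-membered aromatic ring of carbon only, ortho to a large group, ortho to a methoxy group and meta to a methoxy group; read one bond further out, 3,4-dimethoxyphenyl becomes 2,3,4-trimethoxyphenyl.

Among the measured compounds shown here, the one measured step, a 2.3-fold lower number from compound 1 to compound 2 (0.36 log units; beyond the scatter), concerns a different change, exchanging the whole group on the saturated ring carbon, so it shows only that this region matters; no measured pair tests an added methoxy. A small step is therefore expected, a 1.3-fold lower number from compound 2 to compound 3 (0.10 log units; within the scatter), leaning toward a lower number but close to the scatter. For compound 3 the estimated value is 5000 nM, with a range from 2000 nM to 14000 nM.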

Compound 3, concentration for total growth inhibition: 4280 nM
Compound 3: the middle estimate sits 1.2-fold (0.07 log units) above what was measured; the range from low to high includes it.
By their numbers in this assay, from the lowest: compounds 3 and 2 (each within the scatter of the next); then compound 1.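

In this assay, among these compounds, methoxy in place of hydrogen on this aromatic carbon, ortho to a large group, ortho to a methoxy group and meta to a methoxy group, is the first test of an added group on this ring, and the step (a 1.5-fold lower number from compound 2 to compound 3 (0.17 log units; within the scatter)) leaves compound 2 and compound 3 indistinguishable. The 2,3,4-trimethoxyphenyl group still stands apart from 2-phenylethenyl on the saturated ring carbon, by a modest step beyond the scatter (a 3.4-fold lower number from compound 1 to compound 3 (0.54 log units; beyond the scatter)). Nothing measured here explains these numbers.

Going by these compounds, whether another group on this aromatic carbon, such as a hydroxyl, an amine or a carboxylic acid, would move the number beyond the scatter remains open. Also open, on these data alone, is whether the two original methoxy groups are needed at all.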